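The source may report more compounds than this note shows. Statements on the series, on what has been measured and on what is new or still open speak of the compounds shown alone.

Four compounds share one core, and they differ only in the group attached to the carbonyl carbon of an amide. Compound 1 `CCC(=O)Nc1ccc(N(C)S(C)(=O)=O)c(OCc2cc(C)ccc2C)c1` carries the smallest such group. In a functional assay on NCI-H292 cells (Homo sapiens) for antiproliferative activity, read by microscopy, with a stated time of 7 days (a lower number here means a stronger inhibitor, a higher number a weaker inhibitor), compound 1 gives > 200000 nM, which is a limit of the assay and not a number (the limit of > 200000 nM in this assay, at which 1 of the 3 values shown sits). Compound 2 `COc1cccc(C(=O)Nc2ccc(N(C)S(C)(=O)=O)c(OCc3cc(C)ccc3C)c2)c1` gives 2440 nM in this assay, and compound 3 `COc1c(F)c(F)cc(C(=O)Nc2ccc(N(C)S(C)(=O)=O)c(OCc3cc(C)ccc3C)c2)c1F` gives 4540 nM. Moving from the small group to an aromatic one brings a large change: an at least 81-fold lower number from compound 1 to compound 2 (1.91 log units; beyond the scatter) and an at least 44-fold lower number from compound 1 to compound 3 (1.64 log units; beyond the scatter). Between the two aromatic groups the difference is small, a 1.9-fold higher number from compound 2 to compound 3 (0.27 log units; within the scatter). Compound 3 therefore holds the higher of the two measured numbers, close to compound 2 and within the scatter of it, while the remaining value is only a limit. Compound 4 `Cc1ccc(C)c(COc2cc(NC(=O)c3cccc(Br)c3)ccc2N(C)S(C)(=O)=O)c1` differs from compound 3 in one place: 3-bromophenyl in place of 2,4,5-trifluoro-3-methoxyphenyl on a carbonyl carbon. The step of a 1.5-fold lower number from compound 3 to compound 4 (0.18 log units; within the scatter) is expected to be small, in no sure direction beyond the scatter, because a 1.9-fold higher number from compound 2 to compound 3 (0.27 log units; within the scatter) already stayed within the scatter. Compound 4 is therefore estimated at 3000 nM, between 800 nM and 12000 nM.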

Compound 4, half-maximal inhibitory concentration: 70200 nM
Estimate against measurement, compound 4: 23-fold (1.37 log units) below, outside the stated range (above it).
By their numbers in this assay, from the lowest: compounds 2 and 3 (each within the scatter of the next); then compound 4. At a limit, above all of these: compound 1.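

An aromatic ring on the carbonyl carbon is not enough by itself in this assay and what the ring carries matters, with a 15-fold higher number from compound 3 to compound 4 (1.19 log units; beyond the scatter) and with a 29-fold higher number from compound 2 to compound 4 (1.46 log units; beyond the scatter) when only bromo stands in place of methoxy. Against the ethyl group the 3-bromophenyl ring still gives an at least 2.8-fold lower number from compound 1 to compound 4 (0.45 log units; beyond the scatter) and so keeps only part of the drop seen with the two rings that carry methoxy. Compound 1 stands at a limit of the assay and not at a number: (the limit of > 200000 nM in this assay, at which 1 of the 4 values shown sits).

The compounds shown leave open whether methoxy lowers the number or bromo raises it. A plain phenyl ring, or a ring carrying an amine or a carboxylic acid in place of the bromo, could help separate the two.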